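From Iodo to Methoxy on the Aromatic Ring

A few compounds are considered here, and "the series" means these few. Any claim that something is new, unique, unknown or untested is made for them only; others in the source may bear on it.

Of the compounds shown here, three have been tested in an assay on HEK293 cells for inhibition of N-acylethanolamine-hydrolyzing acid amidase (Rattus norvegicus), read by LC-MS, with a stated time of 30 min; on this read-out lower numbers stand for stronger inhibition and higher numbers for weaker inhibition. Compound 1 `Cc1ccc(CCCCCC(=O)N2CCOC2=O)cc1C` sits at the limit of the assay, giving > 20000 nM. Compound 2 `O=C(CCCCCc1cccc(Br)c1)N1CCOC1=O` gives 430 nM. Compound 3 `O=C(CCCCCc1ccc(I)cc1)N1CCOC1=O` also sits at the assay limit, giving > 20000 nM. Compound 3 thus stands at the limit of > 20000 nM in this assay, at which 2 of the 3 values shown sit, an edge of what the assay reports rather than a number. Compound 4 `COc1ccc(CCCCCC(=O)N2CCOC2=O)cc1` differs from compound 3 by methoxy in place of iodo on an aromatic carbon. Within the data shown here, no step between measured compounds is available, so the size of this change can only be estimated. Because compound 3 is at the limit of > 20000 nM in this assay, at which 2 of the 3 values shown sit, the expected step of an at least 1.6-fold lower number from compound 3 to compound 4 (0.22 log units; that floor lies within the scatter) is small, leaving compound 4 weak. Compound 4 is expected to give about 12000 nM, within 3000 nM to 50000 nM.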

Compound 4, half-maximal inhibitory concentration: > 20000 nM
Compound 4 was reported as a limit (the forecaster's own chance of this, stated with the estimate: 55%); middle value at least 1.6-fold (0.22 log units) from the limit.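

Compound 3 and compound 4 both sit at the same assay limit, so no step can be read between them: the limit of > 20000 nM in this assay, at which 3 of the 4 values shown sit.

The compounds shown leave open whether methoxy in place of iodo on an aromatic carbon changes inhibition at all.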